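Cytotoxicity ceiling in the fused-core series: a pyrimidin-2-yl variant

The source may report more compounds than this note shows. Statements on the series, on what has been measured and on what is new or still open speak of the compounds shown alone.

Compound 1 `COc1ccc(-n2c(=O)n(Cc3cc4cc(Cl)ccc4n3CCCC#N)c3cnccc32)c(F)c1` sits at the assay limit in an ADME assay on HeLa cells (Homo sapiens) for cytotoxicity, read by ATP content, with a stated time of 3 days (on this read-out lower numbers stand for higher toxicity in this test and higher numbers for lower toxicity in this test), where compound 1 gives > 50000 nM. Compound 2 `N#CCCCn1c(Cn2c(=O)n(-c3ccncn3)c3ccncc32)cc2cc(Cl)ccc21` also returns a limit; in this assay compound 2 gives > 50000 nM. Compound 3 `N#CCCCn1c(Cn2c(=O)n(-c3ccncc3F)c3ccncc32)cc2cc(Cl)ccc21` likewise returns only a limit, and in this assay compound 3 gives > 50000 nM. Compound 4 `N#CCCCn1c(Cn2c(=O)n(-c3ncccn3)c3ccncc32)cc2cc(Cl)ccc21` remains to be measured. The change is pyrimidin-2-yl in place of 3-fluoropyridin-4-yl on an aromatic nitrogen. The nearest measured steps, a step that the two limits leave unreadable from compound 2 to compound 3 and a step that the two limits leave unreadable from compound 1 to compound 3, cannot be sized, because all three values sit at the limit of > 50000 nM in this assay, at which 3 of the 3 values shown sit. No step beyond the scatter is therefore expected from compound 3 to compound 4, so a number no higher from compound 3 to compound 4 (the limit leaves the size open) is the estimated step. Compound 4 is expected to give 50000 nM in this assay, in the range 25000 nM to 100000 nM, most likely again as a limit.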

Compound 4, half-maximal cytotoxic concentration: > 50000 nM
Compound 4: no number, only a limit (the forecaster's own chance of this, stated with the estimate: 85%); the middle value sits exactly at the limit.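

No step can be read from compound 4 to compound 1, compound 2 or compound 3, because the values in this assay give no numbers to compare: the limit of > 50000 nM in this assay, at which 4 of the 4 values shown sit.

From the compounds shown here alone, how far these four compounds actually lie from one another in this assay stays open.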